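Swapping the pyridinyl ring for a methylsulfonylphenyl group

A few compounds are considered here, and "the series" means these few. Any claim that something is new, unique, unknown or untested is made for them only; others in the source may bear on it.

Of the compounds shown here, two built on one shared core have been measured in a functional assay on Bel-7402 cells (Homo sapiens) for inhibition, read by sulforhodamine B assay, with a stated time of 72 h, tested at 10 uM; a lower number here means less inhibition, a higher number more inhibition at the concentration tested (going by the name of the read-out). Compound 1 `C[C@H](Nc1ncnc2[nH]cnc12)c1nn(-c2cccnc2)c2cc(Cl)ccc12` gives 17%. Compound 2 `C[C@H](Nc1ncnc2[nH]cnc12)c1nn(-c2cccnc2)c2cc(F)ccc12`, which carries fluoro in place of chloro on an aromatic carbon, gives 8%. Of the two numbers, that of compound 2 sits at the bottom, yet the step of a number 9 percentage points lower from compound 1 to compound 2 (within the scatter) lies within the scatter, so the two readings cannot be told apart.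

Compound 3 `C[C@H](Nc1ncnc2[nH]cnc12)c1nn(-c2cccc(S(C)(=O)=O)c2)c2cc(F)ccc12` has not yet been measured. It differs from compound 2 in one place: 3-(methylsulfonyl)phenyl in place of pyridin-3-yl on an aromatic nitrogen. The new group sits on an aromatic nitrogen of the five-membered ring with two nitrogens, part of the fused two-ring system, next to the ring nitrogen.

Within the data shown here, no measured step bears directly on this change. Among the measured compounds shown here, the only known step alters the halogen on an aromatic carbon, not the group on the aromatic nitrogen, and it stayed within the scatter. The numbers of compound 1 and compound 2 in this assay sit close together, so for compound 3 a number level with them is expected. For compound 3 the expected step is a number 4 percentage points higher from compound 2 to compound 3 (within the scatter). Compound 3 is therefore estimated at 12%, with a range from 0% to 35%.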

Compound 3, a percentage reported as inhibition, at one concentration (the size of the read-out at that concentration, not a potency): -16%
Estimate against measurement, compound 3: 28 percentage points above, and the stated range ends above it.
By their numbers in this assay, from the lowest: compound 3; then compounds 2 and 1 (each within the scatter of the next).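

In this assay, among these compounds, the group on the aromatic nitrogen proves to be a place where a change can be read: a number 24 percentage points lower from compound 2 to compound 3 (beyond the scatter) when 3-(methylsulfonyl)phenyl replaces pyridin-3-yl, and this is the only step here that lies beyond the scatter. The halogen swap between compound 1 and compound 2 could not show this, and the direction is towards less inhibition, with compound 3 at -16% as a negative number on a scale of inhibition. Nothing measured alongside these numbers accounts for the drop, so it stands as an observation without a known explanation.

This single step changes two things at once, the ring nitrogen of pyridin-3-yl and the added methylsulfonyl group, so a plain phenyl ring on the same nitrogen would be needed to tell their contributions apart. On these data alone, it also remains open how an amine or a carboxylic acid on that ring would read, and whether the same replacement would give a similar step with the chloro group of compound 1 in place of the fluoro group.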